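Nitro in place of amino, second occurrence in the series

The compounds below may be only part of what the source reports. "The series", "measured", "known", "first", "only" and "open" are said of these compounds alone.

Compound 1 `COc1ccc2c(/C=C/C(=O)c3cc(N)c(OC)c(OC)c3)c[nH]c2c1` and compound 2 `COc1ccc2c(/C=C/C(=O)c3cc(OC)c(OC)c([N+](=O)[O-])c3)c[nH]c2c1` share one core. In a functional assay on A549 cells (Homo sapiens) for antiproliferative activity, read by MTT assay, with a stated time of 48 h (a lower number here means a stronger inhibitor, a higher number a weaker inhibitor), compound 1 gives 193 nM, and compound 2 gives 331 nM. The change between them is nitro in place of amino on an aromatic carbon, and it made a step of a 1.7-fold higher number from compound 1 to compound 2 (0.23 log units; within the scatter). Compound 3 `COc1cc(C(=O)/C=C/c2cn(C)c3ccccc23)cc(N)c1OC` carries another core; the difference between the cores of compound 1 and compound 3 is not broken down here. In this assay compound 3 gives 498 nM, a number within the scatter of compound 2 and beyond the scatter of compound 1. Compound 4 `COc1cc(C(=O)/C=C/c2cn(C)c3ccccc23)cc([N+](=O)[O-])c1OC` has not been measured. It differs from compound 3 by nitro in place of amino on an aromatic carbon, the same change as that from compound 1 to compound 2, with the same surroundings at the place of change. In this assay, going by the values given here, a step of a 1.7-fold higher number from compound 3 to compound 4 (0.23 log units; within the scatter) is expected, beside the earlier 1.7-fold higher number from compound 1 to compound 2 (0.23 log units; within the scatter), which is the only measurement of this change and the sole basis of the expectation. Compound 4 is estimated at 850 nM, with an expected range from 350 nM to 2000 nM.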

Compound 4, half-maximal inhibitory concentration: 1060 nM
Beside the measured number, compound 4's estimate is 1.2-fold (0.10 log units) below it; measured number inside the range.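

In this assay, nitro in place of amino on an aromatic carbon gave a 2.1-fold higher number from compound 3 to compound 4 (0.33 log units; beyond the scatter), a step in the same direction as on the core of compound 1. The two steps do not differ in size beyond what repeated measurements would allow: the same change on two cores in this assay, a 1.7-fold higher number (0.23 log units; within the scatter) from compound 1 to compound 2 and a 2.1-fold higher number (0.33 log units; beyond the scatter) from compound 3 to compound 4, 1.2-fold (0.09 log units) apart, within the scatter of two such steps This supports carrying the change between these two cores, but it rests on one pair per core, and it does not show that the step would hold on any further core or in any other assay, nor does it explain why the step has this direction.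

The compounds shown leave open how other groups would behave at this aromatic carbon, such as a hydroxyl, an acetamide or a methylamine in place of amino or nitro. They also leave open which of the differences between the core of compound 1 and the core of compound 3 matters for the numbers in this assay.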